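Isomeric dimethylpyridin-3-yl groups: from compound 3 to compound 4

The source may report more compounds than this note shows. Statements on the series, on what has been measured and on what is new or still open speak of the compounds shown alone.

In an in vitro ADME assay on microsomes from liver (Homo sapiens) for metabolic stability (on this read-out higher numbers stand for fast clearance and lower numbers for slow clearance), compound 3 `CC[C@H](C)[C@@H]1C(=O)N[C@H](C2Cc3ccccc3C2)C(=O)N1[C@@H](C(=O)N(C)C)c1cnc(C)cc1C` gives 9 mL.min-1.g-1, within the scatter of compound 1 `CC[C@H](C)[C@@H]1C(=O)N[C@H](C2Cc3ccccc3C2)C(=O)N1[C@@H](C(=O)N(C)C)c1ccc(C)nc1C` at 7 mL.min-1.g-1, while compound 2 `CC[C@H](C)[C@@H]1C(=O)N[C@H](C2Cc3ccccc3C2)C(=O)N1[C@@H](C(=O)N(C)C)c1ccc(C)[n+]([O-])c1` gives 1 mL.min-1.g-1. Compound 4 `CC[C@H](C)[C@@H]1C(=O)N[C@H](C2Cc3ccccc3C2)C(=O)N1[C@@H](C(=O)N(C)C)c1cc(C)cnc1C` has 2,5-dimethylpyridin-3-yl in place of 4,6-dimethylpyridin-3-yl on a saturated chain carbon bound to an amide-type nitrogen in a ring and a carbonyl carbon. The closest measured precedent, a 1.3-fold higher number from compound 1 to compound 3 (0.11 log units; within the scatter), is also an exchange between dimethylpyridin-3-yl isomers and stays within the scatter. The larger steps, a 7.0-fold lower number from compound 1 to compound 2 (0.85 log units; beyond the scatter) and a 9.0-fold higher number from compound 2 to compound 3 (0.95 log units; beyond the scatter), lie beyond the scatter but involve the oxygen-bearing group of compound 2, which compound 4 lacks. No step beyond the scatter is therefore expected in this assay, and the estimated step is a 1.1-fold lower number from compound 3 to compound 4 (0.05 log units; within the scatter). For compound 4 the expected value is 8 mL.min-1.g-1, with an estimated range of 4 mL.min-1.g-1 to 16 mL.min-1.g-1.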

Compound 4, intrinsic clearance in microsomes: 5 mL.min-1.g-1
The estimate for compound 4 lay 1.6-fold (0.20 log units) above the measured number, within the range that was stated.
By their numbers in this assay, from the lowest: compound 2; then compounds 4, 1 and 3 (each within the scatter of the next).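

In this assay the third isomer on this saturated chain carbon gives a 1.8-fold lower number from compound 3 to compound 4 (0.26 log units; within the scatter) and a 1.4-fold lower number from compound 1 to compound 4 (0.15 log units; within the scatter) so the three dimethylpyridin-3-yl groups shown remain within the scatter of one another. The oxygen-bearing group of compound 2 also stands apart from this third isomer, with a 5.0-fold higher number from compound 2 to compound 4 (0.70 log units; beyond the scatter) and so its separation does not rest on a single dimethylpyridin-3-yl arrangement. Nothing available bears on the reason for either result.

Open, as far as these compounds go, is how a methoxy group or a carboxylic acid on the pyridin-3-yl ring would read in this assay in place of a methyl group.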